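The compounds below may be only part of what the source reports. "The series", "measured", "known", "first", "only" and "open" are said of these compounds alone.

Compound 1, `CCOc1cc(NC(=O)C2(NC(=O)c3ccc4c(C5CCCC5)c(-c5ncc(Cl)cn5)n(C)c4c3)CCC2)ccc1/C=C/C(=O)OCOP(=O)(O)OC(C)(C)C`: 0.133 h
Compound 2, `CCOc1cc(NC(=O)C2(NC(=O)c3ccc4c(C5CCCC5)c(-c5ncc(Cl)cn5)n(C)c4c3)CCC2)ccc1/C=C/C(=O)OCC(C)C`: 1.42 h

In an ADME assay (liver) for pharmacokinetics, with Liver microsome (Rattus norvegicus) as the target, using microsomes (a higher number here means that the compound lasts longer, a lower number that the compound disappears faster), compound 2 stands highest of the two numbers. For the measured compounds named here, the only measured step, an 11-fold higher number from compound 1 to compound 2 (1.03 log units; beyond the scatter), is large. Compound 3, `CCOc1cc(NC(=O)C2(NC(=O)c3ccc4c(C5CCCC5)c(-c5ncc(Cl)cn5)n(C)c4c3)CCC2)ccc1/C=C/C(=O)OCC(Cl)(Cl)Cl`, carries trichloromethyl in place of isopropyl on a saturated chain carbon bound to an oxygen next to a carbonyl group. That step bears on it only in that it also reshaped the group on the same saturated chain carbon, but it exchanged a different group, so it gives no direction for this change. Compound 3 is therefore expected to stay fairly close to compound 2, a 1.8-fold lower number from compound 2 to compound 3 (0.25 log units; within the scatter), with the half-life of compound 3 estimated at 0.8 h, between 0.3 h and 2.5 h.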

Compound 3, half-life: 0.233 h
Compound 3: middle estimate off by 3.4-fold (0.54 log units), on the high side; the whole stated range lies above it.
By their numbers in this assay, from the lowest: compounds 1 and 3 (each within the scatter of the next); then compound 2.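

In this assay this position on the saturated chain carbon proves sensitive even to a swap between two ring-free groups: trichloromethyl in place of isopropyl gives a 6.1-fold lower number from compound 2 to compound 3 (0.78 log units; beyond the scatter) and so removes most of the standing of compound 2. A further exchange at this same place gives a 1.8-fold higher number from compound 1 to compound 3 (0.24 log units; within the scatter) and so does not separate those two ester groups. Nothing shown accounts for these differences.

The compounds shown leave open whether the drop follows the chlorine atoms themselves or the loss of the isopropyl carbons, and how a 2,2,2-trifluoroethyl or plain ethyl ester would stand in this assay at this place.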